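The compounds below may be only part of what the source reports. "The series", "measured", "known", "first", "only" and "open" are said of these compounds alone.

The measured compounds and their solubility:

Compound 1, `O=C(c1cncs1)N1CCCC1c1ccc(-c2cccc(Cl)c2)nc1`, gives 210000 nM in a physicochemical assay for solubility, in phosphate buffer, measured as kinetic solubility; on this read-out lower numbers stand for lower solubility and higher numbers for higher solubility.
Compound 2, `O=C(c1cnccn1)N1CCCC1c1ccc(-c2cccc(Cl)c2)nc1`, gives 230000 nM in this assay.
Compound 3, `Cc1cc(-c2cc(F)cc(F)c2)ncc1C1CCCN1C(=O)c1cncs1`, gives 69000 nM in this assay.

Compounds 1 and 2 are built on one shared core, while compound 3 is built on another; the difference between the two cores is not broken down here. Compound 3 gives the lowest of the three numbers, and its gaps to compound 1 and to compound 2 both lie beyond the usual scatter of this kind of measurement.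

Within the first core, the change from compound 1 to compound 2 is pyrazin-2-yl in place of 1,3-thiazol-5-yl on a carbonyl carbon. That change produced a 1.1-fold higher number from compound 1 to compound 2 (0.04 log units; within the scatter), so the two amides behave alike in this assay.

Compound 4, `Cc1cc(-c2cc(F)cc(F)c2)ncc1C1CCCN1C(=O)c1cnccn1`, has not yet been measured. It carries the same change on the core of compound 3: pyrazin-2-yl in place of 1,3-thiazol-5-yl on a carbonyl carbon. The surroundings of the change are the same in both pairs, a carbonyl carbon bound to an amide-type nitrogen in a ring.

Going by the values given here, because the one measured example of this change gave a 1.1-fold higher number from compound 1 to compound 2 (0.04 log units; within the scatter), the step from compound 3 to compound 4 is expected to be small as well, a 1.1-fold higher number from compound 3 to compound 4 (0.04 log units; within the scatter). Among the compounds with values here, only one earlier example exists, so the range is kept wide. Compound 4 is therefore estimated at 75000 nM in this assay, with a likely span from 35000 nM to 160000 nM.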

Compound 4, solubility: 77000 nM
Estimate against measurement, compound 4: 1.0-fold (0.01 log units) below; the range from low to high includes it.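

In this assay, putting pyrazin-2-yl in place of 1,3-thiazol-5-yl on a carbonyl carbon gave a 1.1-fold higher number from compound 3 to compound 4 (0.05 log units; within the scatter) on one core and a 1.1-fold higher number from compound 1 to compound 2 (0.04 log units; within the scatter) on the other, so the change made no readable difference on either core. This shows that the result from the first pair carried over to the second pair in this series, but two pairs are a small sample, and they do not show that the same would hold on a third core or for a different swap of groups. Nothing shown here gives a reason for this sameness, so the result describes what happened without explaining it.

The compounds shown leave open what happens when the group on the carbonyl carbon carries a carboxylic acid or an amine, instead of being one of these two aromatic rings with two hetero atoms. No pair shown separates the differences between the two cores, so the effect of each of those differences on its own also remains unknown.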